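Adding a Methyl to a Weak Cell Growth Inhibitor

The source may hold more compounds than are shown below. What is called first, only, known or untested is meant among the compounds shown, and "the series" means these compounds.

Measured so far:
- compound 1, `Cc1ccc(-c2cc(Nc3nnc(-c4ccc(C)cc4)s3)cs2)cc1`: "not determined" (no result reported)
- compound 2, `COc1ccc(-c2nnc(Nc3csc(-c4ccc(C)cc4)c3)s2)cc1`: "not determined" (no result reported)
- compound 3, `Oc1ccc(-c2nnc(Nc3csc(-c4ccccc4)c3)s2)cc1`: 58000 nM

Three compounds of this series have been through the assay, but only one of them came back with a number. In a functional assay on U-373MG ATCC cells (Homo sapiens) for inhibition, read by colorimetric assay and MTT assay, with a stated time of 72 h (on this read-out higher numbers stand for weaker inhibition and lower numbers for stronger inhibition), compound 3 gives 58000 nM. Compound 1 comes back as "not determined" (no result reported) and compound 2 as "not determined" (no result reported), so compound 3 is the only point of reference, and it sits at a weak level of inhibition.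

The next compound, compound 4 `Cc1ccc(-c2cc(Nc3nnc(-c4ccc(O)cc4)s3)cs2)cc1`, keeps the shared core of compound 3 and differs from it in a single spot: methyl in place of hydrogen on an aromatic carbon. Among the measured compounds shown here, no pair of measured compounds shows the effect of such a change, so there is nothing in the data to suggest a move in either direction. The step in this assay is expected to be no change at the digits printed from compound 3 to compound 4 (within the scatter), no larger than the usual scatter of repeated measurements.

Compound 4 is therefore expected to come in at about 58000 nM, within a likely range from 25000 nM to 130000 nM.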

Compound 4, half-maximal inhibitory concentration: 8000 nM
Beside the measured number, compound 4's estimate is 7.3-fold (0.86 log units) above it; the measured number lies below the stated range.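

In this assay, the change from phenyl to 4-methylphenyl gives a 7.3-fold lower number from compound 3 to compound 4 (0.86 log units; beyond the scatter), and a lower number here means stronger inhibition. Among the compounds shown here, this is the first sign that this position, para to a large group, is not indifferent to what sits on it: a single added carbon shifts the result by more than the usual scatter. Nothing available explains how the methyl produces this shift.

This single step cannot show whether the gain belongs to methyl itself or would also come with another group at the same place, such as an ethyl chain, a chlorine atom or an amine. It also leaves open how far inhibition would move with a longer chain there, and whether the same methyl would have a similar effect in a different compound of the series.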